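The source may report more compounds than this note shows. Statements on the series, on what has been measured and on what is new or still open speak of the compounds shown alone.

In a functional assay on MGC-803 cells (Homo sapiens) for inhibition, read by MTT assay, with a stated time of 48 h (a higher number here means a weaker inhibitor, a lower number a stronger inhibitor), three compounds have been measured so far:

Compound 1, `Cc1ccc(NC(=S)NC(=O)c2ccc(OCc3cccc(C(F)(F)F)c3)cc2)cc1-c1nc2ccccc2[nH]1`: 5210 nM
Compound 2, `Cc1ccc(NC(=S)NC(=O)c2ccc(OCc3ccccc3F)cc2)cc1-c1nc2ccccc2[nH]1`: 3070 nM
Compound 3, `Cc1ccc(NC(=O)NC(=O)c2ccc(OCc3cccc(C(F)(F)F)c3)cc2)cc1-c1nc2ccccc2[nH]1`: 13100 nM

Compound 4, `Cc1ccc(NC(=O)NC(=O)c2ccc(OCc3ccccc3F)cc2)cc1-c1nc2ccccc2[nH]1`, has not yet been measured in this assay.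

Compound 1 and compound 2 share one core and differ in a single place: 2-fluorophenyl in place of 3-(trifluoromethyl)phenyl on a saturated chain carbon bound to an oxygen on an aromatic ring. This change gave a 1.7-fold lower number from compound 1 to compound 2 (0.23 log units; within the scatter), a step that stays within the usual scatter, so the two values cannot be told apart with confidence.

Compound 3 carries a different core from compound 1; how the two cores differ is not broken down here. Among the three measured compounds, compound 3 gives the highest number in this assay, and its gap to each of the other two lies beyond the scatter.

Compound 4 is related to compound 3 by the same change that links compound 1 and compound 2: 2-fluorophenyl in place of 3-(trifluoromethyl)phenyl on a saturated chain carbon bound to an oxygen on an aromatic ring. Because that change produced only a 1.7-fold lower number from compound 1 to compound 2 (0.23 log units; within the scatter) on the core of compound 1, the expected step from compound 3 to compound 4 is likewise small, estimated as a 1.6-fold lower number from compound 3 to compound 4 (0.21 log units; within the scatter). Compound 4 is therefore expected to give about 8000 nM in this assay, with a likely range from 3500 nM to 18000 nM.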

Compound 4, half-maximal inhibitory concentration: 2520 nM
Beside the measured number, compound 4's estimate is 3.2-fold (0.50 log units) above it; the whole stated range lies above it.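

In this assay, putting 2-fluorophenyl in place of 3-(trifluoromethyl)phenyl gave a 5.2-fold lower number from compound 3 to compound 4 (0.72 log units; beyond the scatter) on the second core, so on that core the change clearly matters. The same change therefore did not carry over with the same size from one core to the other, and a step measured on one core was a poor guide to the step on the other: the same change on two cores in this assay, a 1.7-fold lower number (0.23 log units; within the scatter) from compound 1 to compound 2 and a 5.2-fold lower number (0.72 log units; beyond the scatter) from compound 3 to compound 4, 3.1-fold (0.49 log units) apart, beyond the scatter of two such steps

This shows that the effect of the change depends on the core it sits on, at least for these two pairs, but two pairs cannot explain why that is, nor give a rule for how the change would behave on a third core.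

The groups shown at this place are only two fluorine-bearing phenyl groups, so the compounds leave open how a phenyl ring carrying a nitrile, an amine or a carboxylic acid would behave on either core. They also leave open whether such groups would show the same dependence on the core that these two pairs do.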